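Compound 3: a new bicyclic group on the amide

This account rests on a few compounds, and the source may have more. Where it says the series, first, only, none or still open, it means among the compounds named here.

Going by the values given here, in a functional assay on A2780 cells (Homo sapiens) for inhibition, read by sulforhodamine B assay, with a stated time of 72 h (a higher number here means a weaker inhibitor, a lower number a stronger inhibitor), compound 2 `O=C(NCc1ccc(S(=O)(=O)c2ccccc2)cc1)c1c[nH]c2ccncc12` gives 2100 nM, the lower of the two numbers so far, and compound 1 `O=C(NCc1ccc(S(=O)(=O)c2ccccc2)cc1)c1nc2cnccc2[nH]1` gives 5400 nM. Compound 3 `O=C(NCc1ccc(S(=O)(=O)c2ccccc2)cc1)c1cnc2nccn2c1` differs from compound 2 by a group of 9 heavy atoms (6 carbon, 3 nitrogen; one five-membered aromatic ring with 2 hetero atoms, one six-membered aromatic ring with 2 hetero atoms) in place of a group of 9 heavy atoms (7 carbon, 2 nitrogen; one five-membered aromatic ring with 1 hetero atom, one six-membered aromatic ring with 1 hetero atom), on a carbonyl carbon, on a carbonyl carbon whose other neighbour is an amide-type nitrogen. Among the compounds with values here, one measured step bears on this change, the modest 2.6-fold lower number from compound 1 to compound 2 (0.41 log units; beyond the scatter), which also exchanged groups of equal size at that carbon. That single step fixes no direction, so a modest to moderate move towards a lower number is expected only tentatively. The estimate for compound 3 is 700 nM, with a range of 60 nM to 5000 nM. This would be an expected 3.0-fold lower number from compound 2 to compound 3 (0.48 log units; beyond the scatter).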

Compound 3, half-maximal inhibitory concentration: 68 nM
Compound 3: middle estimate off by 10-fold (1.01 log units), on the high side; measured number inside the range.
By their numbers in this assay, from the lowest: compound 3; then compound 2; then compound 1.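

In this assay the change at this carbonyl carbon reaches much further than the earlier pair suggested: a 31-fold lower number from compound 2 to compound 3 (1.49 log units; beyond the scatter) and a 79-fold lower number from compound 1 to compound 3 (1.90 log units; beyond the scatter) are both large, though every group compared has the same heavy-atom count. The entering group has 0 hydrogen-bond donors and 3 hydrogen-bond acceptors, against 1 of each in the group it replaces. Nothing available accounts for the gain.

As far as these compounds go, whether the donor count or the ring make-up carries the step remains open. So does the effect of a methyl, a chlorine or an amine on the entering group.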